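The source may report more compounds than this note shows. Statements on the series, on what has been measured and on what is new or still open speak of the compounds shown alone.

In a physicochemical assay for solubility, read by chemiluminescence, in phosphate buffer, measured as kinetic solubility, at pH 7.4 (on this read-out lower numbers stand for lower solubility and higher numbers for higher solubility), three compounds built on a shared core have been measured so far. Compound 3 `O=C(NCC1(c2nc(-c3ccccc3)cs2)CCOCC1)c1ccc(-n2ccnc2)cc1` gives 193000 nM, the highest number of the set. Compound 2 `Cn1ccc(Nc2ccc(C(=O)NCC3(c4nc(-c5ccccc5)cs4)CCOCC3)cc2)n1` gives 48000 nM. Compound 1 `Cc1cnc(Nc2ccc(C(=O)NCC3(c4nc(-c5ccccc5)cs4)CCOCC3)cc2)s1` gives < 1000 nM, which is a limit of the assay and not a number.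

The next compound to be measured is compound 4 `O=C(NCC1(c2nc(-c3ccccc3)cs2)CCOCC1)c1ccc(Nc2ccccn2)cc1`. It carries (pyridin-2-yl)amino in place of 1H-imidazol-1-yl on an aromatic carbon. This brings back a ring attached through an amino link, as in compounds 1 and 2.

Among the compounds with values here, two measured steps bear most directly on this change, since each swaps such an amino-linked ring for 1H-imidazol-1-yl. One is large, an at least 190-fold higher number from compound 1 to compound 3 (2.28 log units; beyond the scatter), and the other is modest, a 4.0-fold higher number from compound 2 to compound 3 (0.60 log units; beyond the scatter). Compound 4 makes the change in the opposite direction, so a lower number is expected. The ring on the amino link also matters, as an at least 48-fold higher number from compound 1 to compound 2 (1.68 log units; beyond the scatter) shows, and this is why the expected range is wide.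

The expected change in this assay is large, a 19-fold lower number from compound 3 to compound 4 (1.29 log units; beyond the scatter). For compound 4 the estimate is 10000 nM, with an expected range from 1500 nM to 60000 nM.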

Compound 4, solubility: 12000 nM
Estimate against measurement, compound 4: 1.2-fold (0.08 log units) below; low and high end bracket the measured number.
By their numbers in this assay, from the lowest: compound 4; then compound 2; then compound 3. At a limit, below all of these: compound 1.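

In this assay, replacing 1H-imidazol-1-yl with (pyridin-2-yl)amino gives a large step, a 16-fold lower number from compound 3 to compound 4 (1.21 log units; beyond the scatter), and compound 3 keeps the highest number of the set, above all three compounds with a ring on an amino link. The ring on that nitrogen also counts on its own, since pyridin-2-yl in place of 1-methyl-1H-pyrazol-3-yl gives a modest step, a 4.0-fold lower number from compound 2 to compound 4 (0.60 log units; beyond the scatter), which places compound 4 under compound 2 with a real number rather than at the bottom of the series. Compound 1 stands at a limit and not at a number, so pyridin-2-yl in place of 5-methyl-1,3-thiazol-2-yl can only be read as a bounded step, an at least 12-fold higher number from compound 1 to compound 4 (1.07 log units; beyond the scatter): the limit of < 1000 nM in this assay, at which 1 of the 4 values shown sits.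

The compounds shown leave open how much of the drop from compound 3 belongs to the amino link itself and how much to the ring it carries, with no pair here that keeps the ring and changes only the link. A plain amine on that aromatic carbon, or a morpholine ring in the same place, would help to separate these two contributions.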